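The compounds below may be only part of what the source reports. "The series", "measured", "known", "first", "only" and "open" are said of these compounds alone.

Compound 1, `N#C/N=C1\N(CCCCCOc2ccc(Cl)cc2)C(=O)C(c2ccccc2)N1c1ccncc1`, gives 373 nM in a functional assay on HONE1 cells for cytotoxicity against HONE1 cell line (Homo sapiens); on this read-out lower numbers stand for stronger inhibition and higher numbers for weaker inhibition. Compound 2, `N#C/N=C1\N(CCCCCCOc2ccc(Cl)cc2)C(=O)C(c2ccccc2)N1c1ccncc1`, gives 337 nM. Compound 3, `N#C/N=C1\N(CCCCCCOc2ccc(Cl)cc2)C(=O)CCN1c1ccncc1`, gives 577 nM.

Compound 4, `N#C/N=C1\N(CCCCCCCOc2ccc(Cl)cc2)C(=O)CCN1c1ccncc1`, has not yet been measured. It differs from compound 3 by a single change: (4-chlorophenoxy)methyl in place of 4-chlorophenoxy on a saturated chain carbon, six bonds along the chain from an amide-type nitrogen in a ring. The same kind of change has already been measured once, from compound 1 to compound 2: (4-chlorophenoxy)methyl in place of 4-chlorophenoxy on a saturated chain carbon, five bonds along the chain from an amide-type nitrogen in a ring. That step read a 1.1-fold lower number from compound 1 to compound 2 (0.04 log units; within the scatter). The two places are not identical: in the earlier pair the chain carbon sits five bonds along the chain from an amide-type nitrogen in a ring, in the new pair six bonds along. The difference between the core of compound 1 and the core of compound 3 is not broken down here. Since the earlier step stayed within the scatter, as a 1.1-fold lower number from compound 1 to compound 2 (0.04 log units; within the scatter) shows, a similarly small step is expected here, a 1.1-fold lower number from compound 3 to compound 4 (0.05 log units; within the scatter). Compound 4 is therefore estimated at 520 nM, likely between 250 nM and 1100 nM.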

Compound 4, half-maximal inhibitory concentration: 3440 nM
Beside the measured number, compound 4's estimate is 6.6-fold (0.82 log units) below it; the whole stated range lies below it.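

In this assay, putting (4-chlorophenoxy)methyl in place of 4-chlorophenoxy gave a 6.0-fold higher number from compound 3 to compound 4 (0.78 log units; beyond the scatter), so the change did not carry over unaltered from one core to the other: the same change on two cores in this assay, a 1.1-fold lower number (0.04 log units; within the scatter) from compound 1 to compound 2 and a 6.0-fold higher number (0.78 log units; beyond the scatter) from compound 3 to compound 4, 6.6-fold (0.82 log units) apart, beyond the scatter of two such steps

A small step on the core of compound 1 therefore does not predict the size of the same step on the core of compound 3. With one pair on each core, and the change sitting five bonds along the chain in one pair and six in the other, these data do not show whether the core or the place on the chain sets the difference.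

From the compounds shown here alone, it remains open what a still longer chain, such as 2-(4-chlorophenoxy)ethyl in place of (4-chlorophenoxy)methyl, would do on either core.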